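A few compounds are considered here, and "the series" means these few. Any claim that something is new, unique, unknown or untested is made for them only; others in the source may bear on it.

Working notes on the series. In an ADME assay on HeLa cells (Homo sapiens) for cytotoxicity, read by MTT assay (a lower number here means a stronger inhibitor, a higher number a weaker inhibitor), compound 3 (`COc1ccc(C[C@H]2COC(=O)[C@@H]2Cc2ccc(OCC(=O)Nc3ccc(C)cc3)c(OC)c2)cc1OC`) gives 228000 nM as its reading. Compound 1 (`CCN(CC)C(=O)CCC(=O)Oc1ccc(C[C@H]2C(=O)OC[C@@H]2Cc2ccc(OC)c(OC)c2)cc1OC`) gives 213000 nM as its reading, and compound 2 (`COc1ccc(C[C@H]2COC(=O)[C@@H]2Cc2ccc(OCc3cn(-c4ccc(Br)cc4)nn3)c(OC)c2)cc1OC`) gives 128000 nM on the same scale. Compound 3 therefore lies within the scatter of both other compounds.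

Compound 4 (`COc1ccc(C[C@H]2COC(=O)[C@@H]2Cc2ccc(OCC(=O)N3CCCCC3)c(OC)c2)cc1OC`) carries piperidin-1-yl in place of (4-methylphenyl)amino on a carbonyl carbon. Within the data shown here, no measured compound carries the piperidin-1-yl group, so no measured step shows this change directly.

Among the measured compounds shown here, two steps bear on it indirectly. The first, a 1.1-fold higher number from compound 1 to compound 3 (0.03 log units; within the scatter), puts a group with a six-membered aromatic ring of carbon only in place of a group with no ring, on an oxygen on an aromatic ring. It is the nearer guide, since the change to compound 4 also removes that aromatic ring. The second, a 1.8-fold higher number from compound 2 to compound 3 (0.25 log units; within the scatter), exchanges (4-methylphenyl)carbamoyl for 1-(4-bromophenyl)-1H-1,2,3-triazol-4-yl. Both steps stay within the scatter.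

On that evidence, the expectation in this assay is no change beyond the scatter, and the estimated step is a 1.1-fold lower number from compound 3 to compound 4 (0.06 log units; within the scatter) in size. The estimate for compound 4 is 200000 nM as a middle value, with an expected range from 100000 nM to 400000 nM for its measurement.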

Compound 4, half-maximal inhibitory concentration: 293000 nM
The estimate for compound 4 lay 1.5-fold (0.17 log units) below the measured number; low and high end bracket the measured number.
By their numbers in this assay, from the lowest: compounds 2, 1, 3 and 4 (each within the scatter of the next, the first and the last beyond it).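

Working notes, continued. In this assay, the change on the carbonyl carbon from (4-methylphenyl)amino to piperidin-1-yl gives (a 1.3-fold higher number from compound 3 to compound 4 (0.11 log units; within the scatter)), so at this position, neither the loss of the amide hydrogen nor the exchange of the aromatic ring for a non-aromatic ring moves the reading beyond the scatter. Among these compounds, with (piperidin-1-yl)carbonyl in place of 1-(4-bromophenyl)-1H-1,2,3-triazol-4-yl, the step (a 2.3-fold higher number from compound 2 to compound 4 (0.36 log units; beyond the scatter)) is the first to pass beyond the scatter, though only modestly, while the step from the open-chain group on the oxygen on an aromatic ring (a 1.4-fold higher number from compound 1 to compound 4 (0.14 log units; within the scatter)) stays within it. Nothing available here bears on the reason for these readings.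

Going by these compounds, whether a morpholin-4-yl group, a simple diethylamino group or a free carboxylic acid on the same carbonyl carbon would leave the reading within the scatter of compound 4 remains open. Also open, on these data alone, is whether a longer chain between the carbonyl carbon and the oxygen on an aromatic ring would leave the reading within that scatter.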